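From oxetan-3-yl to oxolan-3-yl on the aromatic nitrogen

This account rests on a few compounds, and the source may have more. Where it says the series, first, only, none or still open, it means among the compounds named here.

In a toxicity assay on HT-29 cells (Homo sapiens) for cytotoxicity (a lower number here means that less compound is tolerated, a higher number that more compound is tolerated), compound 1 (`CN1C(=S)[C@@H](NC(=O)c2nc(Cc3ccccc3)n(C3CCC3)n2)COc2ccccc21`) gives > 100000 nM as a limit of the assay. Compound 2 (`CN1C(=S)[C@@H](NC(=O)c2nc(Cc3ccccc3)n(C3COC3)n2)COc2ccccc21`) gives > 100000 nM as a limit too, so it stands at the limit of > 100000 nM in this assay, at which 2 of the 2 values shown sit, and no number places it. Compound 3 (`CN1C(=S)[C@@H](NC(=O)c2nc(Cc3ccccc3)n(C3CCOC3)n2)COc2ccccc21`) carries oxolan-3-yl in place of oxetan-3-yl on an aromatic nitrogen. Among the measured compounds shown here, the only measured step at that place is a step that the two limits leave unreadable from compound 1 to compound 2 and it offers no size to carry over. No step beyond the scatter is expected, an estimated a number no higher from compound 2 to compound 3 (the limit leaves the size open) in this assay with no direction favoured. Compound 3 is expected near 100000 nM with an estimated range from 40000 nM to 150000 nM and will most likely read as a limit again.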

Compound 3, half-maximal cytotoxic concentration: > 100000 nM
Compound 3 gave a limit, no number (the forecaster's own chance of this, stated with the estimate: 85%); the middle value lies on the limit itself.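

Among the compounds shown here, compound 1, compound 2 and compound 3 all give only a limit in this assay, so no step among them can be read: the limit of > 100000 nM in this assay, at which 3 of the 3 values shown sit. Going by these compounds, how cyclobutyl, oxetan-3-yl and oxolan-3-yl on the aromatic nitrogen compare in cytotoxic concentration stays open.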